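Working notes: from compound 3 to compound 4

The source may report more compounds than this note shows. Statements on the series, on what has been measured and on what is new or still open speak of the compounds shown alone.

In a functional assay on HL-60 cells (Homo sapiens) for cytotoxicity, read by WST assay, with a stated time of 48 h (on this read-out lower numbers stand for an effect already at smaller amounts and higher numbers for an effect only at larger amounts of compound), compound 1 (`O=C1OC[C@H](Cc2ccccc2)[C@H]1Cc1ccc(Cl)c(Cl)c1`) gives 19000 nM and compound 2 (`COc1ccccc1C[C@H]1COC(=O)[C@@H]1Cc1ccc(Cl)c(Cl)c1`) gives 14000 nM while compound 3 (`O=C1OC[C@H](Cc2cccc(F)c2)[C@H]1Cc1ccc(Cl)c(Cl)c1`) gives 14000 nM on the same read-out. Compound 3 thus stands level with compound 2, and all three values lie within the scatter of one another.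

Compound 4 (`Cc1ccc(C[C@H]2COC(=O)[C@@H]2Cc2ccc(Cl)c(Cl)c2)cc1`) carries 4-methylphenyl in place of 3-fluorophenyl on a saturated chain carbon bound to a saturated ring carbon and is otherwise the same as compound 3.

Among the measured compounds shown here, three measured steps bear on this change, as each alters the same aromatic group. Fluoro in place of hydrogen gave a 1.4-fold lower number from compound 1 to compound 3 (0.13 log units; within the scatter) and methoxy in place of hydrogen gave a 1.4-fold lower number from compound 1 to compound 2 (0.13 log units; within the scatter) while the exchange of 2-methoxyphenyl for 3-fluorophenyl gave no change at the digits printed from compound 2 to compound 3 (within the scatter) as the direct swap of one substituted group for another. None of these steps leaves the scatter. For the measured compounds named here, no measured compound carries a methyl group on this aromatic ring, so the expectation rests on these three compounds alone.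

In this assay the expected step is no change at the digits printed from compound 3 to compound 4 (within the scatter) and nothing beyond the scatter is expected in either direction. Compound 4 is estimated at 14000 nM (expected range 7500 nM to 26000 nM).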

Compound 4, half-maximal effective concentration: 19000 nM
Compound 4: the middle estimate sits 1.4-fold (0.13 log units) below what was measured; the range from low to high includes it.
By their numbers in this assay, from the lowest: compounds 2, 3, 1 and 4 (each within the scatter of the next).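

In this assay 4-methylphenyl in place of 3-fluorophenyl on a saturated chain carbon bound to a saturated ring carbon gives a 1.4-fold higher number from compound 3 to compound 4 (0.13 log units; within the scatter) and, at the same place, 4-methylphenyl in place of 2-methoxyphenyl gives a 1.4-fold higher number from compound 2 to compound 4 (0.13 log units; within the scatter) as the comparison with the other substituted ring. Methyl, a group new to this aromatic ring, gives no change at the digits printed from compound 1 to compound 4 (within the scatter) and so adds a third substituent to methoxy and fluoro, with phenyl, 2-methoxyphenyl, 3-fluorophenyl and 4-methylphenyl all within the scatter of one another at this position. No measurement available here offers an explanation for this flat picture.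

Going by these compounds, whether an amine or a carboxylic acid on this aromatic ring, or a longer chain in place of the methyl, would give a step beyond the scatter stays open. All four compounds also share the dichlorinated aromatic group and the lactone-bearing rest of the core, so the compounds shown say nothing about how the numbers respond to changes there.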